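Sulfonyl-pyridopyrimidinone series: ring-nitrogen substitution on compound 2

This account rests on a few compounds, and the source may have more. Where it says the series, first, only, none or still open, it means among the compounds named here.

Measured compounds in a functional assay on DU-145 cells (Homo sapiens) for inhibition, read by trypan blue exclusion, with a stated time of 72 h; a lower number here means a stronger inhibitor, a higher number a weaker inhibitor:
- compound 1 `COc1ccc(Nc2ncc3cc(S(=O)(=O)c4ccc(Cl)cc4)c(=O)n(C)c3n2)cc1` gives 30000 nM
- compound 2 `O=c1[nH]c2nc(Nc3ccc4[nH]ccc4c3)ncc2cc1S(=O)(=O)c1ccc(F)cc1F` gives 15000 nM
- compound 3 `Cn1c(=O)c(S(=O)(=O)c2ccc(F)cc2F)cc2cnc(Nc3ccc4c(c3)CC(=O)N4)nc21` gives 100000 nM

Compound 2 has the lowest number of the three. Compound 1 is within the scatter of it, so no order between compound 1 and compound 2 can be read from these values. Compound 3 lies beyond the scatter and is the weaker inhibitor of that pair.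

Compound 4 `COC(=O)Cn1c(=O)c(S(=O)(=O)c2ccc(F)cc2F)cc2cnc(Nc3ccc4[nH]ccc4c3)nc21` is not yet measured. It differs from compound 2 in one place: (methoxycarbonyl)methyl in place of hydrogen on an aromatic nitrogen. The entering group is (methoxycarbonyl)methyl, carrying no net charge and no ring, and it sits on an aromatic nitrogen of the shared core, ortho to a fused ring and meta to the (2,4-difluorophenyl)sulfonyl group.

For the measured compounds named here, no measured pair in this set shows the same change, so there is no reference step for it. Compound 1 and compound 3 carry a group of 1 heavy atom on that nitrogen, but they also differ from compound 2 elsewhere, so their values say nothing clean about this position. The expected step from compound 2 to compound 4 is therefore small, a 1.3-fold higher number from compound 2 to compound 4 (0.12 log units; within the scatter), and not clearly beyond the scatter in either direction. For compound 4 the estimated value is 20000 nM, with an expected range from 5000 nM to 80000 nM.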

Compound 4, half-maximal inhibitory concentration: 10000 nM
Compound 4: the middle estimate sits 2.0-fold (0.30 log units) above what was measured; the range from low to high includes it.
By their numbers in this assay, from the lowest: compounds 4, 2 and 1 (each within the scatter of the next, the first and the last beyond it); then compound 3.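

In this assay, for the compounds shown here, the step is a 1.5-fold lower number from compound 2 to compound 4 (0.18 log units; within the scatter) and gives the first clean reading at this aromatic nitrogen of the shared core. Compound 2 and compound 4 cannot be told apart here, so (methoxycarbonyl)methyl, with its 5 heavy atoms, no ring and no net charge, is accepted on that nitrogen in place of hydrogen without a step beyond the scatter. Nothing measured beyond this read-out bears on the step, so the result stands without an explanation.

Still open, as far as these compounds go, is how a carboxylic acid in place of the methyl ester, an amine, or a longer chain on that nitrogen would read against compound 2. Also open, from the compounds shown here alone, is how a group of 1 heavy atom there would read against hydrogen with the rest of compound 2 unchanged, since compound 1 and compound 3 differ from it elsewhere too.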